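The compounds below may be only part of what the source reports. "The series", "measured", "known", "first", "only" and "open" are said of these compounds alone.

Measured so far, in a functional assay on HUVEC cells (Homo sapiens), read by scintillation counting and thymidine incorporation, with a stated time of 24 h; a lower number here means a stronger inhibitor, a higher number a weaker inhibitor:

- compound 1 `CCC(C)n1ncn(-c2ccc(N3CCN(c4ccc(OC[C@@H]5CO[C@@](CN(C)C)(c6ccc(Cl)cc6Cl)O5)cc4)CC3)cc2)c1=O`: 1400 nM
- compound 2 `CCC(C)n1ncn(-c2ccc(N3CCN(c4ccc(OC[C@@H]5CO[C@@](Cn6cnc(C)n6)(c6ccc(Cl)cc6Cl)O5)cc4)CC3)cc2)c1=O`: 272 nM
- compound 3 `CCC(C)n1ncn(-c2ccc(N3CCN(c4ccc(OC[C@@H]5CO[C@@](Cn6cc(C)nc6C)(c6ccc(Cl)cc6Cl)O5)cc4)CC3)cc2)c1=O`: 492 nM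

All three share one core and differ only on a saturated chain carbon bound to a saturated ring carbon. Compound 2 sits at the low end of the three numbers: a 5.1-fold lower number from compound 1 to compound 2 (0.71 log units; beyond the scatter), while a 1.8-fold higher number from compound 2 to compound 3 (0.26 log units; within the scatter). Compound 3 likewise shows a 2.8-fold lower number from compound 1 to compound 3 (0.45 log units; beyond the scatter).

Compound 4 `CCC(C)n1ncn(-c2ccc(N3CCN(c4ccc(OC[C@@H]5CO[C@@](Cn6ncnn6)(c6ccc(Cl)cc6Cl)O5)cc4)CC3)cc2)c1=O` changes compound 2 as follows: 2H-tetrazol-2-yl in place of 3-methyl-1H-1,2,4-triazol-1-yl on a saturated chain carbon bound to a saturated ring carbon. Among the compounds with values here, the only comparable step, one five-membered azole in place of another, is the one from compound 2 to compound 3, and it stayed within the scatter. A further azole swap is therefore expected to move little, so compound 4 is estimated at 350 nM (range 120 nM to 1000 nM), which means an expected 1.3-fold higher number from compound 2 to compound 4 (0.11 log units; within the scatter).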

Compound 4, half-maximal inhibitory concentration: 124 nM
Beside the measured number, compound 4's estimate is 2.8-fold (0.45 log units) above it; the measured number falls inside the stated range.
By their numbers in this assay, from the lowest: compound 4; then compounds 2 and 3 (each within the scatter of the next); then compound 1.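

In this assay the azole at this position does matter: the 2H-tetrazol-2-yl group gives a 2.2-fold lower number from compound 2 to compound 4 (0.34 log units; beyond the scatter) and a 4.0-fold lower number from compound 3 to compound 4 (0.60 log units; beyond the scatter), whereas the earlier swap of one azole for another stayed within the scatter. Replacing dimethylamino with this group gives an 11-fold lower number from compound 1 to compound 4 (1.05 log units; beyond the scatter), the largest step yet at this position. Nothing available explains these steps.

Since the change from compound 2 to compound 4 both alters the ring and removes its methyl, the two effects remain unseparated. An unsubstituted triazole or a methyl-bearing tetrazole would help pull them apart.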